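Thiazolyl Amine Replacing Dichloroanilino in a Phthalazine Series

A few compounds are considered here, and "the series" means these few. Any claim that something is new, unique, unknown or untested is made for them only; others in the source may bear on it.

Measured compounds:
compound 1 `Clc1cccc(Cl)c1Nc1nnc(-c2ccc(Br)cc2)c2ccccc12`, 1700 nM
compound 2 `Brc1ccc(-c2nnc(Sc3nc4ccccc4s3)c3ccccc23)cc1`, 2300 nM

Compound 1 `Clc1cccc(Cl)c1Nc1nnc(-c2ccc(Br)cc2)c2ccccc12` has the lowest of the two numbers in a functional assay on MCF7 cells (Homo sapiens) for antiproliferative activity, read by sulforhodamine B assay, with a stated time of 72 h (a lower number here means a stronger inhibitor, a higher number a weaker inhibitor), where compound 1 gives 1700 nM. Its nearest neighbour is compound 2 `Brc1ccc(-c2nnc(Sc3nc4ccccc4s3)c3ccccc23)cc1`, which in this assay gives 2300 nM; the two values lie within the scatter of each other, so nothing can be said about an order between them. Compound 2 carries a sulfur-linked benzothiazole in place of the anilino group of compound 1, and this exchange left the number essentially unchanged.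

Compound 3 `Brc1ccc(-c2nnc(Nc3nccs3)c3ccccc23)cc1` has not yet been measured in this assay. It differs from compound 1 by 1,3-thiazol-2-yl in place of 2,6-dichlorophenyl on a nitrogen on an aromatic ring. A small heteroaromatic ring on the linker nitrogen thus takes the place of the dichlorinated benzene ring. For the measured compounds named here, with only two measured compounds, and those two within scatter of each other, the data give no step to lean on; the expectation is therefore no change beyond the scatter, with the step from compound 1 to compound 3 estimated as a 1.2-fold higher number from compound 1 to compound 3 (0.07 log units; within the scatter). Compound 3 is expected to give about 2000 nM in this assay, in a range from 700 nM to 6000 nM.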

Compound 3, half-maximal inhibitory concentration: 1400 nM
Compound 3: middle estimate off by 1.4-fold (0.15 log units), on the high side; low and high end bracket the measured number.
By their numbers in this assay, from the lowest: compounds 3, 1 and 2 (each within the scatter of the next).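

For the compounds shown here, with the linker nitrogen and the rest of the molecule kept fixed, this is the first change confined to the ring on that nitrogen, and in this assay it gives a 1.2-fold lower number from compound 1 to compound 3 (0.08 log units; within the scatter). The position therefore accepts a very different ring with no change that can be read: a five-membered aromatic ring with 2 hetero atoms and 5 heavy atoms, with 2 hydrogen-bond acceptors, takes the place of a six-membered carbon ring with 8 heavy atoms, including 2 chlorine, and no hydrogen-bond acceptors. Nothing available explains why the number holds through this exchange.

No step shown here lies beyond the scatter, so it remains unknown what, if anything, at this position can move the number in this assay. As far as these compounds go, it also remains open whether an aminomethyl group or a carboxylic acid on the 1,3-thiazol-2-yl ring, or a longer alkyl chain in place of that ring on the nitrogen, would give a step beyond the scatter.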